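Working notes: chloro for methyl on the pendant phenyl

The source may hold more compounds than are shown below. What is called first, only, known or untested is meant among the compounds shown, and "the series" means these compounds.

Compound 1 `CCOC(=O)c1c(-c2c(Cl)c3ccccc3oc2=O)nn(-c2cccc(Cl)c2)c1C(=O)OCC`: 38000 nM
Compound 2 `CCOC(=O)c1c(-c2c(Cl)c3cc(C)ccc3oc2=O)nn(-c2ccccc2)c1C(=O)OCC`: 108000 nM
Compound 3 `CCOC(=O)c1c(-c2c(Cl)c3cc(C)ccc3oc2=O)nn(-c2cccc(C)c2)c1C(=O)OCC`: 115000 nM

In a functional assay on A549 cells (Homo sapiens) for cytotoxicity, read by MTT assay, with a stated time of 48 h (a lower number here means a stronger inhibitor, a higher number a weaker inhibitor), compound 3 gives the highest of the three numbers. Compound 2 lies within the scatter of compound 3, so no order between them is claimed; compound 1 gives a number beyond the scatter lower than compound 3. Among the compounds with values here, the one measured step, a 1.1-fold higher number from compound 2 to compound 3 (0.03 log units; within the scatter), is within the scatter and concerns a different change.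

Compound 4 `CCOC(=O)c1c(-c2c(Cl)c3cc(C)ccc3oc2=O)nn(-c2cccc(Cl)c2)c1C(=O)OCC` differs from compound 3 by chloro in place of methyl on an aromatic carbon. Within the data shown here, no measured step covers this change directly; compound 1 shares the 3-chlorophenyl of compound 4 but also lacks the methyl on the other aromatic ring, so its lower value is only an indirect hint. The step is therefore expected to be a 1.8-fold lower number from compound 3 to compound 4 (0.25 log units; within the scatter), leaning toward a lower number but plausibly within the scatter. For compound 4 the estimate in this assay is 65000 nM, with a range of 25000 nM to 160000 nM.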

Compound 4, half-maximal inhibitory concentration: 128000 nM
Compound 4: the middle estimate sits 2.0-fold (0.29 log units) below what was measured; measured number inside the range.
By their numbers in this assay, from the lowest: compound 1; then compounds 2, 3 and 4 (each within the scatter of the next).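

In this assay, 3-methylphenyl to 3-chlorophenyl gives no readable difference, with a 1.1-fold higher number from compound 3 to compound 4 (0.05 log units; within the scatter), and chloro in place of hydrogen on the same aromatic carbon is no different, with a 1.2-fold higher number from compound 2 to compound 4 (0.07 log units; within the scatter). The position therefore tolerates hydrogen, methyl and chloro alike on this core, while the methyl on the other ring gives a 3.4-fold higher number from compound 1 to compound 4 (0.53 log units; beyond the scatter). Methyl in place of hydrogen thus carries no single size across the two cores: the same change on two cores in this assay, a 1.1-fold higher number (0.03 log units; within the scatter) from compound 2 to compound 3 and a 3.4-fold higher number (0.53 log units; beyond the scatter) from compound 1 to compound 4, 3.2-fold (0.50 log units) apart, beyond the scatter of two such steps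

As far as these compounds go, whether an amine or a carboxylic acid on this aromatic carbon would move the number beyond the scatter remains open. So does whether any change here can reach the level of compound 1 on the methyl-bearing core.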